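Benzyl esters on a dienoate and trienoate pair

The source may hold more compounds than are shown below. What is called first, only, known or untested is meant among the compounds shown, and "the series" means these compounds.

Three compounds have been measured in a functional assay on Raji cells (Homo sapiens) for cytotoxicity, with a stated time of 72 h; a higher number here means that more compound is needed for the effect, a lower number that less compound is needed:

compound 1, `C=C[C@@](C)(/C=C/c1ccc(O)cc1)CC/C=C/C(=O)OCC`, which reaches only the limit of > 26000 nM;
compound 2, `C=C[C@@](C)(/C=C/c1ccc(O)cc1)CC/C=C/C(=O)OCc1ccccc1`, which also reaches only the limit of > 26000 nM;
compound 3, `C=C[C@@](C)(/C=C/c1ccc(O)cc1)CC/C=C(C)/C=C/C(=O)OCC`, which likewise gives only the limit of > 26000 nM.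

Compound 1 and compound 2 share a core and differ by phenyl in place of methyl on a saturated chain carbon bound to an oxygen next to a carbonyl group. Because both sit at the limit of > 26000 nM in this assay, at which 3 of the 3 values shown sit, the step that the two limits leave unreadable from compound 1 to compound 2 cannot be read as a number. Compound 3 carries a longer unsaturated chain toward the ester; how its core differs from that of compound 1 is not broken down here. Compound 4, `C=C[C@@](C)(/C=C/c1ccc(O)cc1)CC/C=C(C)/C=C/C(=O)OCc1ccccc1`, has not yet been measured. It differs from compound 3 by phenyl in place of methyl on a saturated chain carbon bound to an oxygen next to a carbonyl group, the same kind of change that turns compound 1 into compound 2, occurring twice among these four compounds.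

Within the data shown here, no step here has a readable size, so the expectation for compound 4 rests only on the fact that compound 3 gives > 26000 nM as a limit and that the same change left compound 2 at the limit of > 26000 nM in this assay, at which 3 of the 3 values shown sit. Compound 4 is therefore expected to land near 30000 nM in this assay, most likely reported again as a limit, with a range from 12000 nM to 100000 nM. The step that the limit leaves unreadable from compound 3 to compound 4 is estimated to be small.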

Compound 4, half-maximal effective concentration: > 26000 nM
Compound 4: only a limit was reported; the forecaster's own chance of this, stated with the estimate: 85%; the middle value is on the limit's open side.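

In this assay, among these compounds, compound 4 gives > 26000 nM as a limit and not a number, so the step from compound 3 to compound 4, like the one between compound 1 and compound 2, cannot be read as a size. The compounds shown leave open whether ethyl to benzyl changes the cytotoxicity on either chain, and at what concentration any of the four would reach the half-maximal effect.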